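Permeability of the chlorinated salicylanilide series: compound 3 to compound 4

This account rests on a few compounds, and the source may have more. Where it says the series, first, only, none or still open, it means among the compounds named here.

Measured in an ADME assay for permeability, using PAMPA; on this read-out higher numbers stand for higher permeability and lower numbers for lower permeability:
- compound 1 `O=C(Nc1ccccc1Cl)c1cc(Cl)ccc1O`: 118 10^-6 cm/s
- compound 2 `O=C(Nc1c(Cl)cc([N+](=O)[O-])cc1Cl)c1cc(Cl)ccc1O`: 53 10^-6 cm/s
- compound 3 `O=C(Nc1c(Cl)cc(F)cc1Cl)c1cc(Cl)ccc1O`: 25 10^-6 cm/s

Compound 3 stands lowest of the three, with compound 2 nearest above it and compound 1 furthest. Compound 4 `O=C(Nc1c(Cl)cccc1Cl)c1cc(Cl)ccc1O` follows from compound 3 as hydrogen in place of fluoro on an aromatic carbon. For the measured compounds named here, the one measured step changing the group on that carbon is modest: a 2.1-fold lower number from compound 2 to compound 3 (0.33 log units; beyond the scatter), fluoro in place of nitro. Going by the values given here, no measured step puts hydrogen there. Compound 1, which also has hydrogen on that carbon but differs elsewhere, reads 118 10^-6 cm/s. A small rise in this assay is therefore expected, possibly not beyond the scatter. The expected step is a 1.6-fold higher number from compound 3 to compound 4 (0.20 log units; within the scatter). For compound 4 the estimate is 40 10^-6 cm/s, with an expected range of 18 10^-6 cm/s to 90 10^-6 cm/s.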

Compound 4, apparent permeability in the ADME assay: 73 10^-6 cm/s
For compound 4 the middle estimate is 1.8-fold (0.26 log units) below the measured one; the range from low to high includes it.
By their numbers in the ADME assay, from the lowest: compound 3; then compounds 2, 4 and 1 (each within the scatter of the next, the first and the last beyond it).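

In the ADME assay, hydrogen and fluoro on this carbon read apart, with a 2.9-fold higher number from compound 3 to compound 4 (0.47 log units; beyond the scatter), while hydrogen and nitro do not, with a 1.4-fold higher number from compound 2 to compound 4 (0.14 log units; within the scatter). The added chloro group also gives no readable separation, with a 1.6-fold lower number from compound 1 to compound 4 (0.21 log units; within the scatter). In a physicochemical assay for solubility (on this read-out lower numbers stand for lower solubility and higher numbers for higher solubility), the fluoro-to-hydrogen change gives an at least 2.3-fold lower number from compound 3 to compound 4 (0.36 log units; beyond the scatter), and compound 4 reads 21 ug/mL. In the physicochemical assay compound 3 gives > 49 ug/mL, which is a limit and not a number: the limit of > 49 ug/mL in the physicochemical assay, at which 1 of the 2 values shown sits.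

Open, as far as these compounds go, is how an amine or a methyl group on this carbon would read in either assay. Also open, from the compounds shown here alone, is whether the separation between hydrogen and fluoro holds without the added chloro group.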